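Chloro to fluoro on the aryl ring: two cores compared

The source may hold more compounds than are shown below. What is called first, only, known or untested is meant among the compounds shown, and "the series" means these compounds.

Measured compounds:
compound 1, `Clc1ccc(-c2n[nH]cc2N2CCCNCC2)cc1`, 1230 nM
compound 2, `Fc1ccc(-c2n[nH]cc2N2CCCNCC2)cc1`, 2190 nM
compound 3, `Clc1ccccc1-c1n[nH]cc1N1CCNCC1`, > 10000 nM

In an assay on isolated protein for binding affinity to 5-hydroxytryptamine receptor 1D (Homo sapiens) (a higher number here means a weaker inhibitor, a lower number a stronger inhibitor), compound 1 gives 1230 nM and compound 2 gives 2190 nM. Among the measured compounds shown here, the one change between them is fluoro in place of chloro on an aromatic carbon, and it gives a 1.8-fold higher number from compound 1 to compound 2 (0.25 log units; within the scatter). For compound 3 only a limit of this assay is known: compound 3 gives > 10000 nM, which is the limit of > 10000 nM in this assay, at which 1 of the 3 values shown sits, rather than a number. The difference between the core of compound 3 and the core of compound 1 is not broken down here.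

Compound 4, `Fc1ccccc1-c1n[nH]cc1N1CCNCC1`, has not been measured in this assay. It differs from compound 3 by fluoro in place of chloro on an aromatic carbon. This is the same kind of change as from compound 1 to compound 2, though the place is not the same: in the measured pair the changed atom sits para to a large group, in the new pair it sits ortho to a large group.

Expectation for this assay: with the measured step standing within the scatter, the step from compound 3 to compound 4 is estimated as a step that the limit leaves unreadable from compound 3 to compound 4, resting on the value of compound 3 being a limit and on the measured step of a 1.8-fold higher number from compound 1 to compound 2 (0.25 log units; within the scatter) being small. Compound 4 is therefore expected to give about 20000 nM, with the range 8000 nM to 60000 nM, most likely again as a limit of the assay.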

Compound 4, inhibition constant: > 10000 nM
Compound 4: a limit, no number; the forecaster's own chance of this, stated with the estimate: 85%; the middle value lies beyond the limit too.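

In this assay compound 4 gives > 10000 nM, a limit of the assay and not a number. Compound 3 also stands at a limit, so no step can be read between compound 3 and compound 4: the limit of > 10000 nM in this assay, at which 2 of the 4 values shown sit.

The compounds shown leave open whether fluoro in place of chloro changes the value on the core of compound 3, and what number either compound would give.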